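Shortening a Dodecyloxy Chain in a Chalcone Series

The source may report more compounds than this note shows. Statements on the series, on what has been measured and on what is new or still open speak of the compounds shown alone.

Compound 1, `CCCCCCCCCCCCOc1ccc(C(=O)/C=C/c2c(/C=C/c3ccc(OC)cc3)cc(OC)cc2OC)cc1`: 7.9 ug/mL
Compound 2, `COc1ccc(/C=C/c2cc(OC)cc(OC)c2/C=C/C(=O)c2ccc(Br)cc2)cc1`: 8.3 ug/mL

Of the compounds shown here, two have been measured in a functional assay on A549 cells (Homo sapiens) for antiproliferative activity, read by MTT assay, with a stated time of 48 h; on this read-out higher numbers stand for weaker inhibition and lower numbers for stronger inhibition. Compound 1 gives 7.9 ug/mL in this assay and compound 2 gives 8.3 ug/mL; compound 1 holds the lowest of the two numbers, but the gap to compound 2 lies within the usual scatter, so the two values show no real difference between them.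

Compound 3, `CCOc1ccc(C(=O)/C=C/c2c(/C=C/c3ccc(OC)cc3)cc(OC)cc2OC)cc1`, has not yet been measured in this assay. It differs from compound 1 in one place only: hydrogen in place of decyl on a saturated chain carbon, two bonds along the chain from an oxygen on an aromatic ring. The core shared with compound 1 is kept.

For the measured compounds named here, no pair of measured compounds traces this kind of change, so there is nothing in the numbers so far that tells how much a change on the saturated chain matters in this assay. The expectation is therefore cautious: a step of about a 1.1-fold lower number from compound 1 to compound 3 (0.05 log units; within the scatter) is estimated, which would stay within the scatter, in no clear direction. Compound 3 is thus estimated at 7 ug/mL in this assay, with a range from 2.5 ug/mL to 20 ug/mL.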

Compound 3, half-maximal inhibitory concentration: 7.5 ug/mL
Compound 3: middle estimate off by 1.1-fold (0.03 log units), on the low side; the range from low to high includes it.
By their numbers in this assay, from the lowest: compounds 3, 1 and 2 (each within the scatter of the next).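

Replacing decyl with hydrogen on the saturated chain carbon, two bonds along the chain from an oxygen on an aromatic ring, turns the dodecyl chain into ethyl and gives a 1.1-fold lower number from compound 1 to compound 3 (0.02 log units; within the scatter) in this assay, so even this large loss of chain carbons leaves no real difference in the read-out. Placing ethoxy instead of bromo on an aromatic carbon gives a 1.1-fold lower number from compound 2 to compound 3 (0.04 log units; within the scatter), which shows that, among these compounds, the number also stays within the scatter when a halogen gives way to a short ether. No available evidence explains why neither change shifts the value in this assay.

These compounds leave open whether the same holds for a chain with a carboxylic acid or an amine at its far end, since each chain shown here is made of carbon and hydrogen beyond the oxygen. They also leave open what a hydroxyl group in place of ethoxy would do on the aromatic carbon, and whether the flat result would persist in other cell lines.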